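Propoxy to 4-Fluorophenoxy on the Shared Core

The compounds below may be only part of what the source reports. "The series", "measured", "known", "first", "only" and "open" are said of these compounds alone.

In a functional assay on HCT-116 cells (Homo sapiens) for inhibition, read by sulforhodamine B assay, with a stated time of 48 h, tested at 50 uM (on this read-out lower numbers stand for less inhibition of growth and higher numbers for more inhibition of growth at the one concentration tested), compound 1 (`CCCOc1ccc([C@@H]2CC(=O)c3cc(CC=C(C)C)c(OC)cc3O2)cc1`) gives 63%. Compound 2 (`COc1ccc([C@@H]2C/C(=N/OCc3cn(-c4ccc(C#N)cc4)nn3)c3cc(CC=C(C)C)c(OC)cc3O2)cc1`) gives 50% in this assay, which leaves compound 1 the higher of the two by more than the usual scatter. Compound 3 (`COc1cc2c(cc1CC=C(C)C)C(=O)C[C@@H](c1ccc(Oc3ccc(F)cc3)cc1)O2`) has not yet been measured. It departs from compound 1 in one place: 4-fluorophenyl in place of propyl on an oxygen on an aromatic ring, with 4-fluorophenyl in place of propyl on an oxygen on an aromatic ring. Among the measured compounds shown here, no measured pair shows this change, so the expectation has only one anchor, compound 1 at 63%. The expected step is a number 6 percentage points lower from compound 1 to compound 3 (within the scatter), a small fall that is not expected to lie beyond the scatter, though the uncertainty is wide. The estimate for compound 3 is 57%, with an expected range from 38% to 75%.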

Compound 3, percent growth inhibition at one concentration: 29%
For compound 3 the middle estimate is 28 percentage points above the measured one; the measured number lies below the stated range.
By their numbers in this assay, from the lowest: compound 3; then compound 2; then compound 1.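

In this assay, replacing propyl with 4-fluorophenyl on an oxygen on an aromatic ring gives a number 34 percentage points lower from compound 1 to compound 3 (beyond the scatter), so what this oxygen carries matters to growth inhibition. Compounds 1 and 2 differ in more than one place, so they could not show this for the position alone. Here, a chain of carbon gives way to a six-membered aromatic ring with no change in the counts of donors, acceptors or charge, and the inhibition still drops well beyond the scatter. Nothing measured here accounts for the fall.

From the compounds shown here alone, it remains open whether the fall goes with the ring or with its fluorine, a question that a plain phenyl on this oxygen would separate. Going by these compounds, it is also open whether a longer chain such as hexyl, or a chain ending in an amine, would keep the inhibition seen with propyl.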